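The source may report more compounds than this note shows. Statements on the series, on what has been measured and on what is new or still open speak of the compounds shown alone.

Compound 1 `CS(=O)(=O)c1cc(C(=O)N=C(N)N)c(F)cc1F`, compound 2 `CS(=O)(=O)c1cc(C(=O)N=C(N)N)c(Cl)cc1Cl` and compound 3 `Cc1cc(C)c(S(C)(=O)=O)cc1C(=O)N=C(N)N` share one core and differ only in the groups attached to its ring. In a functional assay for inhibition of sodium/hydrogen exchanger (Oryctolagus cuniculus) (a lower number here means a stronger inhibitor, a higher number a weaker inhibitor), compound 1 gives 630 nM, compound 2 gives 140 nM and compound 3 gives 11 nM. Compound 3 thus stands lowest of the three, with compound 2 nearest and compound 1 furthest, both gaps lying beyond the usual scatter. Compound 4 `CCCCCc1cc(C)c(C(=O)N=C(N)N)cc1S(C)(=O)=O` is not yet measured. It differs from compound 3 by butyl in place of hydrogen on a saturated chain carbon bound to an aromatic carbon, so that a methyl becomes a pentyl. Within the data shown here, no measured pair shows a change of this kind, and the size of the step cannot be read from the data. A modest weakening is expected, a step of a 2.7-fold higher number from compound 3 to compound 4 (0.44 log units; beyond the scatter). Compound 4 is therefore estimated at 30 nM, with a range from 8 nM to 120 nM.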

Compound 4, half-maximal inhibitory concentration: 27 nM
Compound 4: the middle estimate sits 1.1-fold (0.05 log units) above what was measured; measured number inside the range.
By their numbers in this assay, from the lowest: compound 3; then compound 4; then compound 2; then compound 1.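

In this assay, the change of a methyl to a pentyl gives a modest weakening (a 2.5-fold higher number from compound 3 to compound 4 (0.39 log units; beyond the scatter)), which lies beyond the usual scatter. Among these compounds, this is the first single-place change, and it shows that this saturated chain carbon bound to an aromatic carbon can carry butyl in place of hydrogen with only a modest penalty. No measurement here accounts for the size of the step. The compounds shown leave open how a shorter chain such as ethyl, a longer chain such as octyl, or a pentyl ending in an amine would compare.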